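The source may report more compounds than this note shows. Statements on the series, on what has been measured and on what is new or still open speak of the compounds shown alone.

Measured compounds:
Compound 1, `COc1nc2ccc(Br)cc2cc1C(c1ccccc1)n1cc(-c2ccc(Br)cc2)nn1`, gives in an ADME assay on PC-3 cells (Homo sapiens) for cytotoxicity, read by sulforhodamine B assay, with a stated time of 48 h, tested at 10 uM (on this read-out lower numbers stand for less inhibition and higher numbers for more inhibition at the one concentration tested (going by the name of the read-out)), 7.43%.
Compound 2, `CCCCCCCc1cn(C(c2ccccc2)c2cc3cc(Br)ccc3nc2OC)nn1`, gives in this assay 4.42%.
Compound 3, `COc1nc2ccc(Br)cc2cc1C(c1ccccc1)n1cc(-c2ccc(OC(F)(F)F)cc2)nn1`, gives in this assay 21.6%.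

Compound 3 stands highest of the three in this assay, its steps to compound 1 and compound 2 both beyond the scatter. Compound 4, `COc1nc2ccc(Br)cc2cc1C(c1ccccc1)n1cc(-c2ccccc2C(F)(F)F)nn1`, differs from compound 3 in one place: 2-(trifluoromethyl)phenyl in place of 4-(trifluoromethoxy)phenyl on an aromatic carbon. For the measured compounds named here, the step that bears on this is the one changing the group on the same phenyl, a number 14.2 percentage points higher from compound 1 to compound 3 (beyond the scatter), with a number 17.2 percentage points higher from compound 2 to compound 3 (beyond the scatter) also touching that part of the molecule. Going by the values given here, no measured pair exchanges one phenyl substituent for another of this kind, so the direction is unsure; a modest step downward from compound 3 in this assay is expected, since compound 1 sits at 7.43%. Compound 4 is estimated at 12%, within 3% to 25%, a step of a number 9.6 percentage points lower from compound 3 to compound 4 (within the scatter).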

Compound 4, a percentage reported as inhibition, at one concentration (the size of the read-out at that concentration, not a potency): 17.4%
Compound 4: middle estimate off by 5.4 percentage points, on the low side; low and high end bracket the measured number.
By their numbers in this assay, from the lowest: compounds 2, 1, 4 and 3 (each within the scatter of the next, the first and the last beyond it).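

At this aromatic carbon, 2-(trifluoromethyl)phenyl and 4-(trifluoromethoxy)phenyl cannot be told apart in this assay (a number 4.2 percentage points lower from compound 3 to compound 4 (within the scatter)), so this change of substituted phenyl group has no clear effect on the read-out. The new group stands clear of heptyl (a number 13 percentage points higher from compound 2 to compound 4 (beyond the scatter)) but not of 4-bromophenyl (a number 10 percentage points higher from compound 1 to compound 4 (within the scatter)). Nothing available explains these numbers.

The compounds shown leave open how a phenyl group carrying an amine or a carboxylic acid would read at this carbon. A chain shorter than heptyl also remains an open case.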